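A Trichlorophenyl Sulfonamide Built on an Inactive Series

A few compounds are considered here, and "the series" means these few. Any claim that something is new, unique, unknown or untested is made for them only; others in the source may bear on it.

Compound 1, `COc1cccc(S(=O)(=O)NC2=NCCN2C(=S)SN2CCn3c2nsc3=S)c1`: >= 20000 nM (a limit of the assay, not a number)
Compound 2, `CC(=O)Nc1ccc(S(=O)(=O)NC2=NCCN2C(=S)SN2CCn3c2nsc3=S)cc1`: >= 20000 nM (a limit of the assay, not a number)

In a functional assay on KYSE-510 cells (Homo sapiens) for antiproliferative activity, read by crystal violet staining, with a stated time of 96 h (on this read-out higher numbers stand for weaker inhibition of growth and lower numbers for stronger inhibition of growth), compound 1 reaches only a limit. Compound 2 likewise reaches only a limit. Among the measured compounds shown here, the single measured step, a step that the two limits leave unreadable from compound 1 to compound 2, therefore cannot be read, and compound 2 stands at the limit where every value shown sits (the limit of >= 20000 nM in this assay, at which 2 of the 2 values shown sit). Compound 3 `O=S(=O)(NC1=NCCN1C(=S)SN1CCn2c1nsc2=S)c1ccc(Cl)c(Cl)c1Cl` differs from compound 2 as follows: 2,3,4-trichlorophenyl in place of 4-acetamidophenyl on a sulfonyl sulfur. For the measured compounds named here, since the one step between measured compounds, a step that the two limits leave unreadable from compound 1 to compound 2, gives no size, nothing here points to a gain or a loss in this assay beyond the usual scatter, and a further limit is the most likely outcome. Compound 3 is expected to give about 20000 nM, within 6000 nM to 60000 nM. The expected step of a number no higher from compound 2 to compound 3 (the limit leaves the size open) is thus essentially flat.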

Compound 3, concentration for 50% growth inhibition: >= 20000 nM
Compound 3: no number, only a limit; the forecaster's own chance of this, stated with the estimate: 80%; the middle value sits exactly at the limit.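

Compound 3 also gives only a limit of the assay, so the steps to it from compound 1 and compound 2 cannot be read: the limit of >= 20000 nM in this assay, at which 3 of the 3 values shown sit. The compounds shown leave open whether any group on the sulfonyl sulfur can give a measurable value in this assay.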